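The source may hold more compounds than are shown below. What is called first, only, known or untested is meant among the compounds shown, and "the series" means these compounds.

In a functional assay on HepG2 cells (Homo sapiens) for inhibition, read by MTT assay (a lower number here means a stronger inhibitor, a higher number a weaker inhibitor), compound 1 `COc1cc2ncnc(Nc3ccc(NC(=O)c4ccc(C)cc4)cc3)c2cc1OC` gives 25000 nM. Compound 2 `COc1cc2ncnc(Nc3ccc(NC(=O)c4ccc(C(C)(C)C)cc4)cc3)c2cc1OC` reads > 100000 nM, which is a limit of the assay and not a number. Going by the values given here, compound 3 `COc1cc2ncnc(Nc3ccc(NC(=O)c4ccccc4I)cc3)c2cc1OC` gives 33000 nM, close to the only other number, with a 1.3-fold higher number from compound 1 to compound 3 (0.12 log units; within the scatter).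

The next change leads to compound 4 `COc1cc2ncnc(Nc3ccc(NC(=O)c4ccc(I)cc4)cc3)c2cc1OC` and is 4-iodophenyl in place of 2-iodophenyl on a carbonyl carbon. Among the compounds with values here, no measured step moves the iodine itself, so the evidence is indirect. The closest relatives of the 4-iodophenyl group are the 4-methylphenyl and 4-(tert-butyl)phenyl groups, which show an at least 4.0-fold higher number from compound 1 to compound 2 (0.60 log units; beyond the scatter). The 2-iodophenyl group stands against the latter with an at least 3.0-fold lower number from compound 2 to compound 3 (0.48 log units; beyond the scatter), and both of these steps rest on a limit. The step from the 4-methylphenyl group to the 2-iodophenyl group, by contrast, stayed within the scatter.

In this assay no change beyond the scatter is therefore expected, though the risk lies towards a higher number. The expected step is a 1.2-fold higher number from compound 3 to compound 4 (0.08 log units; within the scatter). For compound 4 the estimate is 40000 nM, with an expected range of 15000 nM to 100000 nM.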

Compound 4, half-maximal inhibitory concentration: 40000 nM
Compound 4: the middle estimate sits on the measured number at the digits printed; low and high end bracket the measured number.
By their numbers in this assay, from the lowest: compounds 1, 3 and 4 (each within the scatter of the next). At a limit, above all of these: compound 2.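

In this assay, moving the iodine from the 2-iodophenyl to the 4-iodophenyl group gives the first direct reading of this change, with a 1.2-fold higher number from compound 3 to compound 4 (0.08 log units; within the scatter), so the two placements of the iodine shown here cannot be told apart. Iodo in place of methyl on an aromatic carbon also stays within the scatter, with a 1.6-fold higher number from compound 1 to compound 4 (0.20 log units; within the scatter), which leaves compounds 1, 3 and 4 as one group at this level. Iodo in place of tert-butyl on an aromatic carbon gives an at least 2.5-fold lower number from compound 2 to compound 4 (0.39 log units; beyond the scatter), a step that rests on the limit of compound 2 and not on a number: the limit of > 100000 nM in this assay, at which 1 of the 4 values shown sits.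

Still open, from the compounds shown here alone, is whether an amine or a carboxylic acid on this aromatic carbon would move the number beyond the scatter. Also open, going by these compounds, is whether a longer chain there would track with compound 2 or with compounds 1 and 4.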